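Notes on a cyclohexylamino analogue in the series

A few compounds are considered here, and "the series" means these few. Any claim that something is new, unique, unknown or untested is made for them only; others in the source may bear on it.

Compound 1 `COc1cc2cc(C#N)ccc2c(OC)c1Oc1cc(NC(C)C)nc(Nc2ccc(C#N)cc2)n1` and compound 2 `CCCCCC(C)Nc1cc(Oc2c(OC)cc3cc(C#N)ccc3c2OC)nc(Nc2ccc(C#N)cc2)n1` share one core. In an ADME assay on MT4 cells (Homo sapiens) for cytotoxicity, read by MTT assay, with a stated time of 5 days (on this read-out higher numbers stand for lower toxicity in this test and lower numbers for higher toxicity in this test), compound 1 gives > 125000 nM, which is a limit of the assay rather than a number. In this assay compound 2 likewise gives > 125000 nM, again a limit and not a number. The step that the two limits leave unreadable from compound 1 to compound 2 therefore cannot be read, since both ends sit at the limit of > 125000 nM in this assay, at which 2 of the 2 values shown sit. Compound 3 `COc1cc2cc(C#N)ccc2c(OC)c1Oc1cc(NC2CCCCC2)nc(Nc2ccc(C#N)cc2)n1` differs from compound 2 by cyclohexyl in place of 1-methylhexyl on a nitrogen on an aromatic ring. Going by the values given here, no measured step bears on this change; the only step, a step that the two limits leave unreadable from compound 1 to compound 2, is itself unreadable. The expectation for compound 3 in this assay is therefore that the assay again returns only its limit, with the true value unresolved, so the step that the limit leaves unreadable from compound 2 to compound 3 is expected to lie within the scatter. Compound 3 is estimated at 150000 nM, with a range from 60000 nM to 500000 nM.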

Compound 3, half-maximal cytotoxic concentration: > 125000 nM
Compound 3 was reported as a limit; the forecaster's own chance of this, stated with the estimate: 85%; the middle value does not contradict the limit.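

No new step can be read among compound 1, compound 2 and compound 3, whose values are all limits and not numbers: the limit of > 125000 nM in this assay, at which 3 of the 3 values shown sit. Still open, as far as these compounds go, is whether isopropyl, 1-methylhexyl and cyclohexyl on the nitrogen differ at all in this assay.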